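The source may hold more compounds than are shown below. What is called first, only, known or untested is meant among the compounds shown, and "the series" means these compounds.

Working notes on the series.

Compound 2 `COc1cc(-c2nn(-c3cccc(NC(=O)Nc4cccc(C(F)(F)F)c4)c3)cc2-c2ccncc2)ccc1Cl` gives 811 nM in a functional assay on MDA-MB-231 cells (Homo sapiens) for inhibition, read by sulforhodamine B assay, with a stated time of 48 h; on this read-out lower numbers stand for stronger inhibition of growth and higher numbers for weaker inhibition of growth. Compound 1 `O=C(Nc1cccc(-n2cc(-c3ccncc3)c(-c3ccc(Cl)c(O)c3)n2)c1)Nc1cccc(C(F)(F)F)c1` differs from it by hydrogen in place of methyl on an oxygen on an aromatic ring and gives 3590 nM in this assay, a step of a 4.4-fold higher number from compound 2 to compound 1 (0.65 log units; beyond the scatter). Compound 3 `COc1cc(-c2nn(-c3cccc(NC(=O)Nc4ccc(Cl)c(C(F)(F)F)c4)c3)cc2-c2ccncc2)ccc1Cl` carries the other core; the two cores differ by chloro in place of hydrogen on an aromatic carbon, and compound 3 gives 760 nM in this assay, a step of a 1.1-fold lower number from compound 2 to compound 3 (0.03 log units; within the scatter). Compound 3 and compound 2 therefore sit within the scatter of each other, while both stand apart from compound 1.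

Compound 4 `O=C(Nc1cccc(-n2cc(-c3ccncc3)c(-c3ccc(Cl)c(O)c3)n2)c1)Nc1ccc(Cl)c(C(F)(F)F)c1` is not yet measured. It differs from compound 3 by hydrogen in place of methyl on an oxygen on an aromatic ring, the same change already seen from compound 2 to compound 1, at a place that reads the same in both cases. The expected step from compound 3 to compound 4 is estimated at a 4.3-fold higher number from compound 3 to compound 4 (0.64 log units; beyond the scatter), resting on the earlier step of a 4.4-fold higher number from compound 2 to compound 1 (0.65 log units; beyond the scatter) in the same kind of position. On that basis compound 4 is expected to give about 3300 nM in this assay, with a likely range from 1500 nM to 7500 nM.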

Compound 4, concentration for 50% growth inhibition: 488 nM
Estimate against measurement, compound 4: 6.8-fold (0.83 log units) above, and the stated range ends above it.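

In this assay, the change from methoxy to hydroxy gives a 1.6-fold lower number from compound 3 to compound 4 (0.19 log units; within the scatter), which does not repeat the step seen on the other core: the same change on two cores in this assay, a 4.4-fold higher number (0.65 log units; beyond the scatter) from compound 2 to compound 1 and a 1.6-fold lower number (0.19 log units; within the scatter) from compound 3 to compound 4, 6.9-fold (0.84 log units) apart, beyond the scatter of two such steps

Chloro in place of hydrogen on an aromatic carbon gives a 7.4-fold lower number from compound 1 to compound 4 (0.87 log units; beyond the scatter), which likewise does not match its counterpart on the core of compound 2: the same change on two cores in this assay, a 1.1-fold lower number (0.03 log units; within the scatter) from compound 2 to compound 3 and a 7.4-fold lower number (0.87 log units; beyond the scatter) from compound 1 to compound 4, 6.9-fold (0.84 log units) apart, beyond the scatter of two such steps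

In these four compounds, therefore, the size and direction of a step on one core do not carry over to the other, but a single set of four compounds in one assay shows neither the reason for this nor whether it extends beyond them.

From the compounds shown here alone, it remains open whether the same dependence on the core appears with other groups on that oxygen, such as ethoxy, or with an amine in place of the hydroxy. Going by these compounds, it also remains open whether fluoro or methyl in place of the added chloro would behave as chloro does here.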